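A few compounds are considered here, and "the series" means these few. Any claim that something is new, unique, unknown or untested is made for them only; others in the source may bear on it.

Measured so far:
- Compound 1 `N#Cc1ccc2[nH]c(-c3ccc4[nH]c(-c5ccc6ccccc6c5)nc4c3)nc2c1` gives 130 nM in a functional assay on RPMI 8402 cells (Homo sapiens) for cytotoxicity; on this read-out higher numbers stand for weaker inhibition and lower numbers for stronger inhibition.
- Compound 2 `Cc1ccc(-c2nc3cc(-c4nc5cc(N6CCN(C)CC6)ccc5[nH]4)ccc3[nH]2)cc1` gives 830 nM in this assay.

Of these two numbers, compound 2 stands at the higher one; the gap to compound 1 lies beyond the usual scatter, so compound 1 inhibits more strongly. Compound 3 `CN1CCN(c2ccc3[nH]c(-c4ccc5[nH]c(-c6ccc7ccccc7c6)nc5c4)nc3c2)CC1` differs from compound 2 by naphthalen-2-yl in place of 4-methylphenyl on an aromatic carbon. Among the compounds with values here, no measured pair shows this change alone, so its size is uncertain. Compound 1 carries the same naphthalen-2-yl group and gives 130 nM, which suggests a moderate move toward lower numbers. Compound 3 is expected to give 400 nM, with a range from 150 nM to 1100 nM. That estimate means an expected step of a 2.1-fold lower number from compound 2 to compound 3 (0.32 log units; beyond the scatter).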

Compound 3, half-maximal inhibitory concentration: 110 nM
Estimate against measurement, compound 3: 3.6-fold (0.56 log units) above; measured number below the stated range.
By their numbers in this assay, from the lowest: compounds 3 and 1 (each within the scatter of the next); then compound 2.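

Within the data shown here, on the aromatic carbon between two ring nitrogen atoms, naphthalen-2-yl in place of 4-methylphenyl gives a 7.5-fold lower number from compound 2 to compound 3 (0.88 log units; beyond the scatter) in this assay, the first direct reading of this change. With naphthalen-2-yl held fixed, 4-methylpiperazin-1-yl in place of cyano gives a 1.2-fold lower number from compound 1 to compound 3 (0.07 log units; within the scatter), so this swap shows no readable change. No measurement here explains either result. As far as these compounds go, whether that swap would also show no readable change with 4-methylphenyl remains open. So does how a plain phenyl group, or an amine on that ring, would read at this position.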